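Thiosemicarbazone series: fluoro for cyano on the aryl ring

The source may report more compounds than this note shows. Statements on the series, on what has been measured and on what is new or still open speak of the compounds shown alone.

compound 1 `NC(=S)N/N=C/c1cc2cccnc2s1`: > 100000 nM
compound 2 `N#Cc1ccc(NC(=S)N/N=C/c2ccc3ccccc3n2)cc1`: 15600 nM

Two compounds have been run in a functional assay on HT-29 cells (Homo sapiens) for antiproliferative activity, read by sulforhodamine B assay, with a stated time of 72 h; a higher number here means a weaker inhibitor, a lower number a stronger inhibitor. For compound 1 the reading > 100000 nM is a limit of the assay and not a number; it sits at the limit of > 100000 nM in this assay, at which 1 of the 2 values shown sits. Among the compounds with values here, compound 2, built on a different core, gives 15600 nM in this assay, and this is the only numerical value in the set, so compound 2 stands alone as the sole measured point. Within the data shown here, no step between measured compounds can be drawn, because compound 1 and compound 2 differ in more than one place and one of them is only a limit.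

Compound 3 `Fc1ccc(NC(=S)N/N=C/c2ccc3ccccc3n2)cc1` keeps the core of compound 2 and differs from it in one place: fluoro in place of cyano on an aromatic carbon. Among the measured compounds shown here, nothing measured here bears on that exchange, so the expectation rests on the single number for compound 2. The expected step in this assay is small, within the scatter or slightly toward weaker inhibition: a 1.4-fold higher number from compound 2 to compound 3 (0.15 log units; within the scatter). Compound 3 is therefore estimated at 22000 nM in this assay, with a range from 7000 nM to 70000 nM.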

Compound 3, half-maximal inhibitory concentration: 28500 nM
Compound 3: the middle estimate sits 1.3-fold (0.11 log units) below what was measured; measured number inside the range.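

In this assay, fluoro in place of cyano on an aromatic carbon, para to a large group, gives a 1.8-fold higher number from compound 2 to compound 3 (0.26 log units; within the scatter), so 4-cyanophenyl and 4-fluorophenyl cannot be told apart at this position. Within the data shown here, this is the first one-place comparison: the value of compound 2 no longer stands alone, and the nitrile at this position is not required for a reading of this order, as compound 3 carries fluoro there instead. Nothing measured here bears on why the two groups read alike.

Only cyano and fluoro are shown at this position, so whether an amine, a carboxylic acid or a longer alkyl chain there would move the number beyond the scatter stays open. Going by these compounds, compound 1 gives > 100000 nM, which is a limit of the assay, and it differs from compound 2 in more than one place, so what the core and the aryl group each contribute also stays open.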